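From trifluorophenyl to dimethylphenyl, starting at a limit

The source may report more compounds than this note shows. Statements on the series, on what has been measured and on what is new or still open speak of the compounds shown alone.

Compound 1 `Cc1ccc(/C=C2\SC(=S)N(NS(=O)(=O)c3ccccc3)C2=O)cc1`: > 50000 nM, a limit
Compound 2 `O=C1/C(=C/c2cc(F)c(F)cc2F)SC(=S)N1NS(=O)(=O)c1ccccc1`: > 50000 nM, a limit

In a functional assay on ECV-304 cells (Homo sapiens) for cytotoxicity (on this read-out lower numbers stand for stronger inhibition and higher numbers for weaker inhibition), compound 2 stands only at a limit, > 50000 nM. Compound 3 `Cc1ccc(/C=C2\SC(=S)N(NS(=O)(=O)c3ccccc3)C2=O)cc1C` departs from it by one change: 3,4-dimethylphenyl in place of 2,4,5-trifluorophenyl on a double-bonded chain carbon bound to a double-bonded ring carbon. Among the measured compounds shown here, the only measured step is a step that the two limits leave unreadable from compound 1 to compound 2, and the data show (the limit of > 50000 nM in this assay, at which 2 of the 2 values shown sit). Compound 1 carries 4-methylphenyl at that place and gives > 50000 nM, also a limit. On that showing, no step beyond the scatter is expected in this assay. The step expected is a step that the limit leaves unreadable from compound 2 to compound 3. Compound 3 is estimated at 60000 nM, with an expected range of 25000 nM to 100000 nM.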

Compound 3, half-maximal inhibitory concentration: > 50000 nM
Compound 3 ended at the assay's limit; the forecaster's own chance of this, stated with the estimate: 85%; the middle value is on the limit's open side.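

Among the compounds shown here, compound 3 gives > 50000 nM as a limit in this assay and so, like compound 1 and compound 2, yields no step that can be read. As far as these compounds go, whether these aromatic groups differ at all in cytotoxicity stays open.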